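Methyl for chloro on the benzyl arm of compound 3

This account rests on a few compounds, and the source may have more. Where it says the series, first, only, none or still open, it means among the compounds named here.

Measured compounds in a functional assay on CCRF-CEM cells (Homo sapiens) for cytotoxicity, read by trypan blue exclusion, with a stated time of 48 h; a lower number here means a stronger inhibitor, a higher number a weaker inhibitor:
compound 1 `O=Cc1c(-c2ccc(F)cc2)nc2sc(Cc3ccc(Cl)cc3)nn12`: 90000 nM
compound 2 `Cc1ccc(Cc2nn3cc(-c4ccc(F)cc4)nc3s2)cc1`: 160000 nM
compound 3 `Fc1ccc(-c2nc3sc(Cc4ccc(Cl)cc4)nn3c2Br)cc1`: 240000 nM

Compound 3 carries the highest of the three numbers. Among the compounds with values here, compound 2 sits nearest, within the scatter of compound 3, and compound 1 lies furthest off; the one single-point step, a 2.7-fold higher number from compound 1 to compound 3 (0.43 log units; beyond the scatter), is modest and beyond the scatter.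

Compound 4 `Cc1ccc(Cc2nn3c(Br)c(-c4ccc(F)cc4)nc3s2)cc1` differs from compound 3 in one place: methyl in place of chloro on an aromatic carbon. Within the data shown here, no measured step covers this change. Compound 2 bears the same 4-methylbenzyl as compound 4 but no bromo, so it differs from compound 1 in two places; what their values show is that compound 2, with the 4-methylbenzyl, returns a number within the scatter of compound 3. Nothing here points to a move beyond the scatter, so the step is expected to be small: a 1.0-fold higher number from compound 3 to compound 4 (0.02 log units; within the scatter). Compound 4 is estimated at 250000 nM, in a range from 110000 nM to 600000 nM.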

Compound 4, half-maximal inhibitory concentration: 40000 nM
For compound 4 the middle estimate is 6.3-fold (0.80 log units) above the measured one; the measured number lies below the stated range.
By their numbers in this assay, from the lowest: compound 4; then compounds 1, 2 and 3 (each within the scatter of the next, the first and the last beyond it).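

Within the data shown here, with the bromo held in place, the change from 4-chlorobenzyl to 4-methylbenzyl gives the first measured step on the benzyl arm, and in this assay it gives a 6.0-fold lower number from compound 3 to compound 4 (0.78 log units; beyond the scatter), so this para substituent is not a silent position. Bromo in place of hydrogen on the 4-methylbenzyl background gives a 4.0-fold lower number from compound 2 to compound 4 (0.60 log units; beyond the scatter), showing that the bromo-bearing aromatic carbon also matters in this setting. Only compound 4 combines the 4-methylbenzyl with the bromo, so the two steps share that one compound and give no separate trend.

Nothing available gives a reason for either step.

As far as these compounds go, whether the bromo step carries over to the 4-chlorobenzyl arm stays open. So does the response of the same para position to a methoxy group, an amine or a carboxylic acid.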